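The compounds below may be only part of what the source reports. "The series", "measured", "known", "first", "only" and "open" are said of these compounds alone.

Series of aryl-methyl ethers on a shared core built from compound 2 `COc1ccc(OCCOCCNC2CCCC2)cc1`, compound 1 `c1ccc(COc2ccc(OCCOCCNC3CCCC3)cc2)cc1` and compound 3 `O=[N+]([O-])c1ccccc1COc1ccc(OCCOCCNC2CCCC2)cc1`. Within the data shown here, in a functional assay on SK-OV-3 cells (Homo sapiens) for inhibition, read by CCK-8 assay, with a stated time of 70 h (on this read-out lower numbers stand for stronger inhibition and higher numbers for weaker inhibition), compound 3 gives 5370 nM, the lowest of the three numbers measured so far. Compound 1 gives 24800 nM, and compound 2 gives 99100 nM; the step of a 4.6-fold lower number from compound 1 to compound 3 (0.66 log units; beyond the scatter) is modest, the step of an 18-fold lower number from compound 2 to compound 3 (1.27 log units; beyond the scatter) is large, and the step of a 4.0-fold higher number from compound 1 to compound 2 (0.60 log units; beyond the scatter) is modest.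

Compound 4 `Cc1ccc(COc2ccc(OCCOCCNC3CCCC3)cc2)cc1` is not yet measured. It differs from compound 3 by 4-methylphenyl in place of 2-nitrophenyl on a saturated chain carbon bound to an oxygen on an aromatic ring. Among the measured compounds shown here, two measured steps bear on this: the nitro is lost, which mirrors the reverse of the step from compound 1 to compound 3, and the ring itself is kept, so the large step from compound 2 to compound 3 argues against falling back as far as compound 2. For the measured compounds named here, no measured step tells what the methyl adds; compound 1 is the closest reference for a bare aromatic ring at this position.

Compound 4 is therefore expected to sit near compound 1, with a step of a 3.4-fold higher number from compound 3 to compound 4 (0.53 log units; beyond the scatter) in this assay. The estimate for compound 4 is 18000 nM, with a range from 6000 nM to 50000 nM.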

Compound 4, half-maximal inhibitory concentration: 17200 nM
Compound 4: the middle estimate sits 1.0-fold (0.02 log units) above what was measured; the measured number falls inside the stated range.
By their numbers in this assay, from the lowest: compound 3; then compounds 4 and 1 (each within the scatter of the next); then compound 2.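

In this assay, the methyl group makes no readable difference on the aromatic ring: the step of a 1.4-fold lower number from compound 1 to compound 4 (0.16 log units; within the scatter) lies within the scatter, so compound 1 and compound 4 stand at one level. The gain over the hydrogen of compound 2 therefore holds with a second aromatic ring, with or without the methyl, as the step of a 5.8-fold lower number from compound 2 to compound 4 (0.76 log units; beyond the scatter) shows alongside the earlier result for compound 1. The 2-nitrophenyl group stays apart from the 4-methylphenyl group, with a 3.2-fold higher number from compound 3 to compound 4 (0.51 log units; beyond the scatter) in the same assay, so among compounds 1, 3 and 4 only compound 3 departs from the level of the plain and methylated rings, and no measurement shown accounts for that departure.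

Compound 3 and compound 4 differ in both the group and its place on the aromatic ring, so the compounds shown do not separate the nitro group itself from where it sits. As far as these compounds go, how an amine or a carboxylic acid on this ring would read in this assay also remains open, as does whether any such group would match the nitro group.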